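Hydroxy for Methoxy, Carried from One Core to Another

The source may report more compounds than this note shows. Statements on the series, on what has been measured and on what is new or still open speak of the compounds shown alone.

Measured in a functional assay on HCT-116 cells (Homo sapiens) for cytotoxicity, with a stated time of 48 h; a lower number here means a stronger inhibitor, a higher number a weaker inhibitor:
compound 1, `COc1cc(OC)c(C(=O)/C=C/c2ccccc2SC)c(OC)c1`, gives 6800 nM
compound 2, `COc1cccc(/C=C/C(=O)c2c(OC)cc(OC)cc2OC)c1`, gives 4300 nM
compound 3, `COc1cc(O)c(C(=O)/C=C/c2ccccc2SC)c(OC)c1`, gives 10000 nM

Compound 2 shows the lowest of the three numbers, but compound 1 sits close to it, with a 1.6-fold lower number from compound 1 to compound 2 (0.20 log units; within the scatter). Compound 3 stands furthest away, giving 10000 nM, while compound 2 gives 4300 nM, a gap that lies beyond the scatter. The two cores differ only in one group: 3-methoxyphenyl in place of 2-(methylsulfanyl)phenyl on a double-bonded chain carbon bound to a double-bonded chain carbon. Within the core of compound 1 the single change hydrogen in place of methyl on an oxygen on an aromatic ring produced a 1.5-fold higher number from compound 1 to compound 3 (0.17 log units; within the scatter), a step that stays within the scatter.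

The same change made on compound 2 gives compound 4, `COc1cccc(/C=C/C(=O)c2c(O)cc(OC)cc2OC)c1`, which is yet to be measured in this assay. The difference between compound 2 and compound 4 reads (hydrogen in place of methyl on an oxygen on an aromatic ring), and its place is described in the same words as for the earlier pair, so the two changes are the same change and it occurs twice among the compounds shown. For the measured compounds named here, the step from compound 2 to compound 4 is expected to be about a 1.5-fold higher number from compound 2 to compound 4 (0.18 log units; within the scatter), resting on the single earlier example, because a 1.5-fold higher number from compound 1 to compound 3 (0.17 log units; within the scatter) was small. Going by the values given here, with only one precedent the range is kept wide. Compound 4 is therefore estimated at 6500 nM in this assay, with 2500 nM and 17000 nM as the ends of the expected span.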

Compound 4, half-maximal inhibitory concentration: 7700 nM
The estimate for compound 4 lay 1.2-fold (0.07 log units) below the measured number; the range from low to high includes it.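

In this assay, the change of methoxy to hydroxy on the core of compound 2 gave a 1.8-fold higher number from compound 2 to compound 4 (0.25 log units; within the scatter), so the step seen on the core of compound 1 has a counterpart on a second core carrying 3-methoxyphenyl in place of 2-(methylsulfanyl)phenyl. Set side by side, the two steps point the same way and do not differ in size by more than repeated measurements would: the same change on two cores in this assay, a 1.5-fold higher number (0.17 log units; within the scatter) from compound 1 to compound 3 and a 1.8-fold higher number (0.25 log units; within the scatter) from compound 2 to compound 4, 1.2-fold (0.09 log units) apart, within the scatter of two such steps What this shows is limited to these two pairs: on both cores the exchange of methyl for hydrogen on an oxygen on an aromatic ring left the number within the scatter, and it does not show that the exchange has a real effect in this assay, nor that the same result would hold on any further core.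

The compounds shown leave open whether a longer chain on that oxygen, such as ethoxy, or an amine in place of the hydroxy would give a step of similar size. They also leave open whether the step would hold on a core with a chloro group or a carboxylic acid in place of 3-methoxyphenyl and 2-(methylsulfanyl)phenyl.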